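This account rests on a few compounds, and the source may have more. Where it says the series, first, only, none or still open, it means among the compounds named here.

Of the compounds shown here, three sharing one core have been measured in a functional assay on Ehrlich cells (Mus musculus) for cytotoxicity, tested at 100 ug/mL; on this read-out lower numbers stand for a weaker effect and higher numbers for a stronger effect at the one concentration tested. Compound 1 `COc1cc(N2C(N)=C(C#N)C(c3cccc([N+](=O)[O-])c3)C3=C2CC(C)(C)CC3=O)cc(OC)c1OC` gives 30%. Compound 2 `COc1cc(N2C(N)=C(C#N)C(c3ccc([N+](=O)[O-])cc3)C3=C2CC(C)(C)CC3=O)cc(OC)c1OC` gives 80%. Compound 3 `COc1cc(N2C(N)=C(C#N)C(c3ccc(O)cc3)C3=C2CC(C)(C)CC3=O)cc(OC)c1OC` gives 100%, the highest of the three numbers: its nearest neighbour is compound 2, and a number 20 percentage points higher from compound 2 to compound 3 (beyond the scatter), while the furthest is compound 1, and a number 70 percentage points higher from compound 1 to compound 3 (beyond the scatter). Between the two lower compounds, a number 50 percentage points higher from compound 1 to compound 2 (beyond the scatter).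

Compound 4 `COc1cc(N2C(N)=C(C#N)C(/C=C/c3ccccc3)C3=C2CC(C)(C)CC3=O)cc(OC)c1OC` has not yet been measured in this assay. It differs from compound 3 in a single place: 2-phenylethenyl in place of 4-hydroxyphenyl on a saturated ring carbon. Every measured step changes either the group on that saturated ring carbon or a substituent on it, so all three bear on the new change, the two ending at compound 3 being large and modest in size. None of them, however, exchanges the aromatic ring at that carbon for a 2-phenylethenyl group, and none removes the hydroxy group, so their direction cannot simply be carried over. Compound 3 already stands at the top of the read-out. A large rise is therefore not expected, and a modest fall is estimated: a number 30 percentage points lower from compound 3 to compound 4 (beyond the scatter). In this assay compound 4 is expected to give 70%, in a range from 35% to 100%.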

Compound 4, a percentage reported as activity, at one concentration (the size of the read-out at that concentration, not a potency): 40%
The estimate for compound 4 lay 30 percentage points above the measured number; measured number inside the range.
By their numbers in this assay, from the lowest: compounds 1 and 4 (each within the scatter of the next); then compound 2; then compound 3.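

Moving from either 4-substituted phenyl group to 2-phenylethenyl on this saturated ring carbon lowers the read-out in this assay: a number 60 percentage points lower from compound 3 to compound 4 (beyond the scatter), and a number 40 percentage points lower from compound 2 to compound 4 (beyond the scatter). So among the groups shown at this carbon, a high number is not kept by the carbon-only 2-phenylethenyl group, with its double bond outside aromatic rings and no hydrogen-bond donor or acceptor, while the 4-hydroxyphenyl and 4-nitrophenyl groups both give higher numbers. Against the third aromatic group the picture differs, with a number 10 percentage points higher from compound 1 to compound 4 (within the scatter), so 2-phenylethenyl and 3-nitrophenyl cannot be told apart here, and no available evidence accounts for any of these steps.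

As far as these compounds go, it remains open whether the drop from compound 3 goes with losing the hydroxy group or with the double bond, which an unsubstituted phenyl group or a 2-(4-hydroxyphenyl)ethenyl group on this carbon could separate. From the compounds shown here alone, how a 4-aminophenyl or 4-carboxyphenyl group would stand is also open, as is whether these differences at one concentration would hold as differences in potency.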